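A few compounds are considered here, and "the series" means these few. Any claim that something is new, unique, unknown or untested is made for them only; others in the source may bear on it.

Notes on the series.

Compound 1 `O=C1C(=O)N(CN2CCN(c3ccnc4cc(Cl)ccc34)CC2)c2cccc(Cl)c21` carries a chloro group on the isatin-type ring and, in a functional assay on MDA-MB-468 cells (Homo sapiens) for cytotoxicity, read by sulforhodamine B assay, with a stated time of 48 h (a higher number here means a weaker inhibitor of growth, a lower number a stronger inhibitor of growth), compound 1 gives 37800 nM. Compound 2 `O=C1C(=O)N(CN2CCN(c3ccnc4cc(Cl)ccc34)CC2)c2cccc(Br)c21` differs from compound 1 by bromo in place of chloro on an aromatic carbon; in this assay compound 2 gives 15900 nM, so that the step of a 2.4-fold lower number from compound 1 to compound 2 (0.38 log units; beyond the scatter) is the one clear movement so far.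

Compound 3 `O=C1C(=O)N(CN2CCN(c3ccnc4cc(C(F)(F)F)ccc34)CC2)c2cc(Cl)ccc21` has a trifluoromethyl group in place of the chloro on the quinoline part and the chloro on the other ring placed differently; the difference between the core of compound 3 and the core of compound 1 is not broken down here. In this assay compound 3 gives 26100 nM, which sits within the scatter of both compound 1 and compound 2.

Compound 4 `O=C1C(=O)N(CN2CCN(c3ccnc4cc(C(F)(F)F)ccc34)CC2)c2cc(Br)ccc21` is to compound 3 what compound 2 is to compound 1: the change is bromo in place of chloro on an aromatic carbon. It is the same kind of change as from compound 1 to compound 2, not the same one, since in compound 4 the halogen sits meta to a fused ring and para to a fused ring, whereas in compound 2 it sits ortho to a fused ring and meta to a fused ring.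

Going by the values given here, on the single precedent of a 2.4-fold lower number from compound 1 to compound 2 (0.38 log units; beyond the scatter), a similar but somewhat smaller step is expected, roughly a 1.7-fold lower number from compound 3 to compound 4 (0.24 log units; within the scatter), the surroundings of the halogen being different and only one example to rest on. The estimate for compound 4 in this assay is 15000 nM, with an expected range from 7000 nM to 35000 nM.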

Compound 4, concentration for 50% growth inhibition: 24800 nM
The estimate for compound 4 lay 1.7-fold (0.22 log units) below the measured number; measured number inside the range.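

In this assay, bromo in place of chloro on an aromatic carbon now gives a 1.1-fold lower number from compound 3 to compound 4 (0.02 log units; within the scatter), whereas the earlier step on the core of compound 1 was a 2.4-fold lower number from compound 1 to compound 2 (0.38 log units; beyond the scatter). Set side by side, the two steps do not separate beyond what repeated measurements allow: the same change on two cores in this assay, a 2.4-fold lower number (0.38 log units; beyond the scatter) from compound 1 to compound 2 and a 1.1-fold lower number (0.02 log units; within the scatter) from compound 3 to compound 4, 2.3-fold (0.35 log units) apart, within the scatter of two such steps. Going by these compounds alone, this shows no demonstrated dependence of the change on the core, but it does not show that the change carries over either, since only one of the two steps lies beyond the scatter, only two pairs are available, and the pairs differ both in the group on the quinoline part and in where the halogen sits.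

A pair with the halogen placed as in compound 4 but with chloro on the quinoline part would separate those two differences, and the same holds for a pair with the halogen placed as in compound 2 and trifluoromethyl on the quinoline part. Also open is how fluoro, iodo, methoxy, nitrile or an amine on the aromatic carbon now holding the halogen would read in this assay, since the compounds shown carry only chloro and bromo there.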